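Two amine swaps on one shared core, one expectation

The compounds below may be only part of what the source reports. "The series", "measured", "known", "first", "only" and "open" are said of these compounds alone.

In an assay on CHO cells for displacement of a labelled ligand from 5-hydroxytryptamine receptor 1D (Homo sapiens) (a higher number here means a weaker inhibitor, a lower number a stronger inhibitor), compound 1 `c1ccc2c(c1)CCC2NC1CCN(CCCc2c[nH]c3ccc(-n4cnnc4)cc23)CC1` gives 8.9 nM. Compound 2 `CC(=O)Nc1ccc(CNC2CCN(CCCc3c[nH]c4ccc(-n5cnnc5)cc34)CC2)cc1` gives 3 nM in this assay, and compound 3 `c1ccc2c(c1)CCC2NCC1CCN(CCCc2c[nH]c3ccc(-n4cnnc4)cc23)CC1` gives 1.1 nM, the lowest of the three numbers. The change from compound 1 to compound 2 is 4-acetamidobenzyl in place of 2,3-dihydro-1H-inden-1-yl on an amine nitrogen; it brought a 3.0-fold lower number from compound 1 to compound 2 (0.47 log units; beyond the scatter). The cores of compound 1 and compound 3 differ by ((2,3-dihydro-1H-inden-1-yl)amino)methyl in place of (2,3-dihydro-1H-inden-1-yl)amino on a saturated ring carbon, which gave an 8.1-fold lower number from compound 1 to compound 3 (0.91 log units; beyond the scatter).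

Compound 4 `CC(=O)Nc1ccc(CNCC2CCN(CCCc3c[nH]c4ccc(-n5cnnc5)cc34)CC2)cc1` has not yet been measured in this assay. It differs from compound 3 by 4-acetamidobenzyl in place of 2,3-dihydro-1H-inden-1-yl on an amine nitrogen. Among the compounds with values here, this is the same kind of change as the one from compound 1 to compound 2, but not the same: in compound 1 the amine nitrogen's other neighbour is a saturated ring carbon, in compound 3 it is a saturated chain carbon. The expected step is a 2.2-fold lower number from compound 3 to compound 4 (0.34 log units; beyond the scatter), resting on the earlier swap, which brought a 3.0-fold lower number from compound 1 to compound 2 (0.47 log units; beyond the scatter), and kept somewhat smaller since the surroundings of the amine differ. Compound 4 is therefore expected to give about 0.5 nM in this assay, with a range from 0.15 nM to 1.5 nM.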

Compound 4, half-maximal inhibitory concentration: 4.2 nM
Estimate against measurement, compound 4: 8.4-fold (0.92 log units) below, and the stated range ends below it.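

In this assay the swap to 4-acetamidobenzyl did not carry over from one core to the other: on the core of compound 3 it gave a 3.8-fold higher number from compound 3 to compound 4 (0.58 log units; beyond the scatter), so the step changed direction. Set side by side, the two steps do not agree: the same change on two cores in this assay, a 3.0-fold lower number (0.47 log units; beyond the scatter) from compound 1 to compound 2 and a 3.8-fold higher number (0.58 log units; beyond the scatter) from compound 3 to compound 4, 11-fold (1.05 log units) apart, beyond the scatter of two such steps. This shows that, for these two pairs, the result of replacing 2,3-dihydro-1H-inden-1-yl with 4-acetamidobenzyl depends on the core that carries it, so the step on one core cannot be taken over for the other; it does not show which feature of the cores is responsible, nor how the change would behave on any further core.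

On these data alone, it remains open whether a plain benzyl on the same amine nitrogen, without the acetamido group, would follow the direction seen in compound 2 or that seen in compound 4. As far as these compounds go, the outcome of this swap with a longer chain carrying the amine is also open.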